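The source may hold more compounds than are shown below. What is called first, only, known or untested is meant among the compounds shown, and "the series" means these compounds.

Three compounds sharing one core were tested in a functional assay on KOPN-8 cells (Homo sapiens) for antiproliferative activity, with a stated time of 72 h; on this read-out lower numbers stand for an effect already at smaller amounts and higher numbers for an effect only at larger amounts of compound. Compound 1 `COc1ccc(-c2c(Cl)c(=O)c3c(OC)cc(OC)cc3n2S(=O)(=O)c2ccc(OC)cc2)cc1` gives 19100 nM. Compound 2 `COc1ccc(-c2cc(=O)c3c(OC)cc(OC)cc3n2S(=O)(=O)c2cc(F)c(F)c(F)c2)cc1` reaches only the limit of this assay, > 65500 nM, so no real number stands for it. Compound 3 `COc1ccc(-c2cc(=O)c3c(OC)cc(OC)cc3n2S(=O)(=O)c2c(C(C)C)cc(C(C)C)cc2C(C)C)cc1` likewise gives only a limit, > 341000 nM. Compound 4 `COc1ccc(-c2cc(=O)c3c(OC)cc(OC)cc3n2S(=O)(=O)c2ccc(Br)s2)cc1` has not yet been measured; it differs from compound 2 in one place (5-bromothiophen-2-yl in place of 3,4,5-trifluorophenyl on a sulfonyl sulfur). Among the compounds with values here, no step between two measured compounds isolates this kind of change, so the expectation rests on little. Compound 2 shows only a limit, which leaves the direction open. The estimated step of an at least 1.6-fold lower number from compound 2 to compound 4 (0.21 log units; that floor lies within the scatter) is expected to be small, within the usual scatter. Compound 4 is estimated at 40000 nM, with a range from 10000 nM to 160000 nM, and a fair chance that only a limit is reported.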

Compound 4, half-maximal effective concentration: > 48200 nM
Compound 4 ended at the assay's limit; the forecaster's own chance of this, stated with the estimate: 45%; middle value at least 1.2-fold (0.08 log units) away from the limit.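

Within the data shown here, compound 2 and compound 4 both give only a limit in this assay, and no step between them can be read. On these data alone, whether 5-bromothiophen-2-yl or 3,4,5-trifluorophenyl on a sulfonyl sulfur gives the lower number stays open.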